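Carbonyl substituent changes in the diethylmethylene series

The compounds below may be only part of what the source reports. "The series", "measured", "known", "first", "only" and "open" are said of these compounds alone.

Measured so far:
compound 1 `CCn1c(C(=O)N(C)CCC#N)ccc1C(CC)(CC)c1ccc(OCC(=O)C(C)(C)C)c(C)c1`: 9800 nM
compound 2 `C=CCN(C)C(=O)c1ccc(C(CC)(CC)c2ccc(OCC(=O)C(C)(C)C)c(C)c2)n1CC`: 21600 nM
compound 3 `CCn1c(C(=O)OC(C)CCO)ccc1C(CC)(CC)c1ccc(OCC(=O)C(C)(C)C)c(C)c1`: 380 nM

In an assay on HL-60 cells for agonist activity at vitamin D3 receptor (Homo sapiens), read by microscopy, with a stated time of 96 h (a lower number here means that less compound is needed, a higher number that more compound is needed for the effect), compound 3 gives 380 nM and stands lowest of the three numbers. Compound 1 gives 9800 nM and compound 2 gives 21600 nM in this assay; both carry a nitrogen on the carbonyl where compound 3 carries an oxygen. The steps to compound 3 were large: a 26-fold lower number from compound 1 to compound 3 (1.41 log units; beyond the scatter) and a 57-fold lower number from compound 2 to compound 3 (1.75 log units; beyond the scatter). Between the two nitrogen-bearing compounds the step was modest: a 2.2-fold higher number from compound 1 to compound 2 (0.34 log units; beyond the scatter).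

Compound 4 `CCn1c(C(=O)Nc2cccc(C(F)(F)F)c2)ccc1C(CC)(CC)c1ccc(OCC(=O)C(C)(C)C)c(C)c1` differs from compound 3 in that (a group of 11 heavy atoms (7 carbon, 1 nitrogen, 3 fluorine; one six-membered aromatic ring of carbon only) in place of a group of 6 heavy atoms (4 carbon, 2 oxygen; no ring), on a carbonyl carbon). This again puts a nitrogen on the carbonyl, though now carrying an aromatic ring rather than the chains seen in compound 1 and compound 2. For the measured compounds named here, the two large steps toward compound 3 bear on it and point to a large step back upward in this assay; the aromatic substituent has no measured precedent here, so the spread is wide. Compound 4 is expected at 5000 nM (range 700 nM to 35000 nM), a step of a 13-fold higher number from compound 3 to compound 4 (1.12 log units; beyond the scatter) from compound 3.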

Compound 4, half-maximal effective concentration: > 50000 nM
Compound 4: only a limit was reported; the forecaster's own chance of this, stated with the estimate: 5%; middle value at least 10-fold (1.00 log units) away from the limit.
By their numbers in this assay, from the lowest: compound 3; then compound 1; then compound 2. At a limit, above all of these: compound 4.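

In this assay the reading for compound 4 is a limit and not a number: the limit of > 50000 nM in this assay, at which 1 of the 4 values shown sits. On this carbonyl carbon, the (3-(trifluoromethyl)phenyl)amino group in place of the oxygen-linked chain gives an at least 130-fold higher number from compound 3 to compound 4 (2.11 log units; beyond the scatter). The nitrogen-linked groups also differ among themselves, with the aromatic one past both chain amides in an at least 2.3-fold higher number from compound 2 to compound 4 (0.36 log units; beyond the scatter) and an at least 5.1-fold higher number from compound 1 to compound 4 (0.70 log units; beyond the scatter), so all three nitrogen-linked compounds stand on the high side of the single oxygen-linked one, with no compound shown going against this.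

The compounds shown do not separate the effect of the oxygen on the carbonyl from that of the hydroxyl-bearing chain attached to it. A carboxylic acid, a methyl ester or an amide carrying the same hydroxyl-bearing chain would bear directly on that question.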